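The compounds below may be only part of what the source reports. "The series", "measured", "known", "first", "only" and "open" are said of these compounds alone.

Measured in a functional assay on HeLa cells (Homo sapiens) for inhibition; a higher number here means a weaker inhibitor, a lower number a stronger inhibitor:
- compound 1 `Cc1cn(C)c(=O)n(/C=C/C=O)c1=O`: 15000 nM
- compound 2 `O=C/C=C/n1cc(F)c(=O)[nH]c1=O`: 40000 nM
- compound 3 `Cc1cn(/C=C/C#N)c(=O)[nH]c1=O`: > 100000 nM

Compound 3 gives no number, only a limit of the assay: the limit of > 100000 nM in this assay, at which 1 of the 3 values shown sits.

Compound 4 `Cc1cn(/C=C/C=N/O)c(=O)[nH]c1=O` is the next compound to be tested in this assay. Its structural change from compound 3 is a group of 3 heavy atoms (1 carbon, 1 nitrogen, 1 oxygen; no ring) in place of a group of 2 heavy atoms (1 carbon, 1 nitrogen; no ring), on a double-bonded chain carbon bound to a double-bonded chain carbon.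

Going by the values given here, no measured pair shows this change directly. Compound 2, whose chain ends in a carbonyl, gives 40000 nM, and on that value a moderate step toward stronger inhibition is expected. The estimated step is an at least 1.6-fold lower number from compound 3 to compound 4 (0.22 log units; that floor lies within the scatter).

Compound 4 is estimated at 60000 nM, with an expected range of 20000 nM to 100000 nM.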

Compound 4, half-maximal inhibitory concentration: > 100000 nM
Compound 4: a limit, no number; the forecaster's own chance of this, stated with the estimate: 35%; middle value at least 1.6-fold (0.22 log units) from the limit.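

No step from compound 3 to compound 4 can be read, since both give a limit and not a number: the limit of > 100000 nM in this assay, at which 2 of the 4 values shown sit.

On these data alone, whether replacing cyano with the group in compound 4 changes inhibition at all remains open.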